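Hydrogen for Methyl at a Saturated Carbon: Cytotoxicity Outlook

The source may hold more compounds than are shown below. What is called first, only, known or untested is meant among the compounds shown, and "the series" means these compounds.

Compound 1 `Cn1c(Cc2ccccc2C(F)(F)F)nc(C(=O)NCC2CCCCC2)c(O)c1=O` and compound 2 `CC(c1ccccc1C(F)(F)F)c1nc(C(=O)NCc2ccccc2)c(O)c(=O)n1C` were both examined in an ADME assay on HepG2 cells (Homo sapiens) for cytotoxicity, in the presence of a further agent that is not named here; on this read-out higher numbers stand for weaker inhibition and lower numbers for stronger inhibition. In this assay compound 2 returns only a limit, > 100000 nM. Compound 1 likewise returns only a limit, > 100000 nM. Hence (the limit of > 100000 nM in this assay, at which 2 of the 2 values shown sit), and compound 2 stands at that limit together with the other value. Compound 3 `Cn1c(Cc2ccccc2C(F)(F)F)nc(C(=O)NCc2ccccc2)c(O)c1=O` differs from compound 2 by hydrogen in place of methyl on a saturated chain carbon bound to two aromatic carbons. Within the data shown here, no measured pair differs in a single place, so the step is expected to be none beyond the scatter. Compound 3 is therefore expected to give 150000 nM, within a range from 50000 nM to 500000 nM. The expected step that the limit leaves unreadable from compound 2 to compound 3 is thus essentially flat.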

Compound 3, half-maximal inhibitory concentration: > 100000 nM
Compound 3 gave a limit, no number; the forecaster's own chance of this, stated with the estimate: 85%; the middle value does not contradict the limit.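

Among these compounds, no step from compound 2 to compound 3, or from compound 1 to compound 3, can be read in this assay, since each compound gives only a limit: the limit of > 100000 nM in this assay, at which 3 of the 3 values shown sit. The compounds shown leave open whether hydrogen in place of methyl, or phenyl in place of cyclohexyl, changes the read-out at all.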